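The compounds below may be only part of what the source reports. "The series", "measured", "known", "first", "only" and "open" are said of these compounds alone.

Measured so far in a physicochemical assay for lipophilicity, at pH 7.4; a higher number here means a more lipophilic compound, a lower number a more polar compound
compound 1 `CCS(=O)(=O)c1ccc2c(c1)C(c1cnn(C)c1)=CN(C)C(=O)[C@@H]2C` gives 2.8
compound 2 `C[C@H]1C(=O)N(C)C=C(c2cn[nH]c2)c2cc([C@H](O)CO)ccc21` gives 0.8

Compound 2 stands lowest of the two at 0.8 in these notes, and its gap to compound 1 lies beyond the scatter.

The next step is small: methyl in place of hydrogen on an aromatic nitrogen turns the 1H-pyrazol-4-yl of compound 2 into the 1-methyl-1H-pyrazol-4-yl of compound 3 `C[C@H]1C(=O)N(C)C=C(c2cnn(C)c2)c2cc([C@H](O)CO)ccc21` and leaves the rest unchanged. Among the measured compounds shown here, no measured pair shows this change alone, so the expectation rests on the structural change and has no direct precedent in the data. A modest rise in this assay is expected, probably just beyond the scatter and well short of the gap between compound 1 and compound 2. The estimate takes a number 0.40 log units higher from compound 2 to compound 3 (beyond the scatter) as the expected step for now. The expected reading puts compound 3 at 1.2 with 0.8 to 1.7 as its estimated range for now.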

Compound 3, distribution coefficient: 1.3
Compound 3: the middle estimate sits 0.10 log units below what was measured; the measured number falls inside the stated range.
By their numbers in this assay, from the lowest: compound 2; then compound 3; then compound 1.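

In this assay, among the compounds shown here, methyl in place of hydrogen on an aromatic nitrogen gives a number 0.50 log units higher from compound 2 to compound 3 (beyond the scatter); this is the first reading of that nitrogen of the 1H-pyrazol-4-yl as a single change, with the rest of the structure held constant. Compound 3 also isolates the other place, where 1,2-dihydroxyethyl in place of ethylsulfonyl on an aromatic carbon gives a number 1.50 log units lower from compound 1 to compound 3 (beyond the scatter), a larger step than the methyl change. No available evidence bears on the origin of either step.

Going by these compounds, each change rests on one pair, so it remains open whether the methyl step holds with ethylsulfonyl on the aromatic carbon. Also open, on these data alone, is how an ethyl group on the aromatic nitrogen, or an amine or a carboxylic acid in place of 1,2-dihydroxyethyl, would read in this assay.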